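This account rests on a few compounds, and the source may have more. Where it says the series, first, only, none or still open, it means among the compounds named here.

Measured compounds:
- Compound 1 `CCCCCCCCCCCCn1nnc(C(C(=O)Nc2c(C(C)C)cccc2C(C)C)c2nnn[nH]2)n1`: 8%
- Compound 2 `CCCCCCCCCCCCn1nnc(C(C(=O)Nc2c(C(C)C)cccc2C(C)C)c2ccccn2)n1`: 24%

Both compounds share a long dodecyl chain on a tetrazole ring, an amide linking to a diisopropylphenyl group, and a saturated chain carbon that carries a further ring. In an assay on isolated protein for inhibition of sterol O-acyltransferase 1 (Mus musculus), tested at 0.1 uM (a lower number here means less inhibition, a higher number more inhibition at the concentration tested (going by the name of the read-out)), compound 1 gives 8% and compound 2 gives 24%. Within the data shown here, compound 2 stands highest of the two numbers; the one step measured so far, a number 16 percentage points higher from compound 1 to compound 2 (beyond the scatter), is a modest rise that lies beyond the scatter.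

Compound 3 `CCCCCCCCCCCCn1nnc(CC(=O)Nc2c(C(C)C)cccc2C(C)C)n1` has not yet been measured. Its difference from compound 2 is hydrogen in place of pyridin-2-yl on a saturated chain carbon bound to an aromatic carbon and a carbonyl carbon. Among the measured compounds shown here, the measured step concerns an exchange of one ring for another on that saturated chain carbon; no step shows what happens when the ring is removed altogether and only a hydrogen remains. With both measured values sitting low, the new number is expected to stay in the same low region, with no confident direction for a number 9 percentage points lower from compound 2 to compound 3 (within the scatter). For compound 3 the expected value in this assay is therefore 15%, within a range from 0% to 40%.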

Compound 3, a percentage reported as inhibition, at one concentration (the size of the read-out at that concentration, not a potency): 91%
Compound 3: middle estimate off by 76 percentage points, on the low side; measured number outside the range, above it.
By their numbers in this assay, from the lowest: compound 1; then compound 2; then compound 3.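

In this assay, the change that matters at this saturated chain carbon is whether it carries a ring at all: leaving only hydrogen there gives a number 67 percentage points higher from compound 2 to compound 3 (beyond the scatter) when pyridin-2-yl leaves, and a number 83 percentage points higher from compound 1 to compound 3 (beyond the scatter) when 1H-tetrazol-5-yl leaves. Both of these steps are far larger than the one ring-for-ring exchange, a number 16 percentage points higher from compound 1 to compound 2 (beyond the scatter), so among these three compounds the choice of ring counts for much less than the presence of either ring, and the unsubstituted carbon gives by far the most inhibition at the concentration tested. No measurement shown here offers a reason for this large difference.

On these data alone, it remains open whether a group much smaller than a ring, such as a methyl or an amine on the same carbon, would keep inhibition as high as in compound 3, or would already lower it as the two rings do. As far as these compounds go, all three compounds also carry the dodecyl chain and the diisopropylphenyl amide, so how a shorter chain such as octyl would alter the picture remains unknown as well.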